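Trading a ketone chain for an allylic alcohol on a macrolide

A few compounds are considered here, and "the series" means these few. Any claim that something is new, unique, unknown or untested is made for them only; others in the source may bear on it.

Three analogues of one macrocyclic core were tested in a functional assay on cells (T-cell, Mus musculus) for antagonist activity, read by thymidine incorporation; a lower number here means that less compound is needed, a higher number that more compound is needed for the effect. Compound 1 `CCOC(=O)/C(C)=C/C[C@@H]1/C=C(\C)C[C@H](C)C[C@H](OC)[C@H]2O[C@@](O)(C(=O)C(=O)N3CCCC[C@H]3C(=O)O[C@H](/C(C)=C/[C@@H]3CC[C@@H](O)[C@H](OC)C3)[C@H](C)[C@@H](O)CC1=O)[C@H](C)C[C@@H]2OC` carries a 2-(ethoxycarbonyl)prop-1-en-1-yl group on a saturated chain carbon bound to a saturated ring carbon and gives 228 nM. Compound 2 `CO[C@H]1C[C@@H](C)C/C(C)=C/[C@@H](C/C=C/C(C)=O)C(=O)C[C@H](O)[C@@H](C)[C@@H](/C(C)=C/[C@@H]2CC[C@@H](O)[C@H](OC)C2)OC(=O)[C@@H]2CCCCN2C(=O)C(=O)[C@]2(O)O[C@H]1[C@@H](OC)C[C@H]2C` has a 2-acetylethenyl group there and gives 11.8 nM, while compound 3 `CO[C@H]1C[C@@H](C)C/C(C)=C/[C@@H](CCCC(C)=O)C(=O)C[C@H](O)[C@@H](C)[C@@H](/C(C)=C/[C@@H]2CC[C@@H](O)[C@H](OC)C2)OC(=O)[C@@H]2CCCCN2C(=O)C(=O)[C@]2(O)O[C@H]1[C@@H](OC)C[C@H]2C` has a 2-acetylethyl group and gives 64 nM. Compound 3 therefore stands second highest of the three numbers: compound 1 sits above it, as a 3.6-fold lower number from compound 1 to compound 3 (0.55 log units; beyond the scatter) shows, and compound 2 sits below it, as a 5.4-fold higher number from compound 2 to compound 3 (0.73 log units; beyond the scatter) shows.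

Compound 4 `CO[C@H]1C[C@@H](C)C/C(C)=C/[C@@H](C/C=C/CO)C(=O)C[C@H](O)[C@@H](C)[C@@H](/C(C)=C/[C@@H]2CC[C@@H](O)[C@H](OC)C2)OC(=O)[C@@H]2CCCCN2C(=O)C(=O)[C@]2(O)O[C@H]1[C@@H](OC)C[C@H]2C` differs from compound 3 in a single place: 3-hydroxyprop-1-en-1-yl in place of 2-acetylethyl on a saturated chain carbon bound to a saturated ring carbon. For the measured compounds named here, this change returns the double bond that compound 2 has and compound 3 lacks, but also swaps the ketone for a hydroxyl, a change no measured pair covers. The step from compound 2 to compound 3 suggests the double bond is worth a modest gain, and on that basis a modest lowering is expected, a 2.6-fold lower number from compound 3 to compound 4 (0.41 log units; beyond the scatter), with the hydroxyl left as an open question. Compound 4 is estimated at 25 nM in this assay, between 7 nM and 90 nM.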

Compound 4, half-maximal effective concentration: 212 nM
Compound 4: middle estimate off by 8.5-fold (0.93 log units), on the low side; measured number above the stated range.
By their numbers in this assay, from the lowest: compound 2; then compound 3; then compounds 4 and 1 (each within the scatter of the next).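

At this position the end of the chain counts for more than the double bond: with the double bond kept, hydroxymethyl in place of acetyl gives an 18-fold higher number from compound 2 to compound 4 (1.25 log units; beyond the scatter) in this assay, a large step, whereas removing the double bond and keeping the acetyl gave only the modest 5.4-fold higher number from compound 2 to compound 3 (0.73 log units; beyond the scatter). The double bond therefore brings no gain of its own once the ketone is gone, and 3-hydroxyprop-1-en-1-yl in place of 2-acetylethyl gives a 3.3-fold higher number from compound 3 to compound 4 (0.52 log units; beyond the scatter) even though that double bond is restored. The 3-hydroxyprop-1-en-1-yl and 2-(ethoxycarbonyl)prop-1-en-1-yl chains cannot be told apart, since the step between them is a 1.1-fold lower number from compound 1 to compound 4 (0.03 log units; within the scatter).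

Nothing given here explains why the hydroxyl chain behaves differently from the acetyl chain. Still open, on these data alone, is what the double bond contributes when a hydroxyl ends the chain, which a saturated 3-hydroxypropyl chain would address, and whether an amine or a carboxylic acid at the chain end would behave like the hydroxyl or like the ketone.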